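A new ring on the sulfur of compound 2

The source may report more compounds than this note shows. Statements on the series, on what has been measured and on what is new or still open speak of the compounds shown alone.

In a functional assay on SMMC-7721 cells (Homo sapiens) for inhibition, read by CCK-8 assay, with a stated time of 72 h, tested at 2 uM (a higher number here means more inhibition of growth at the concentration tested, a lower number less inhibition of growth), compound 1 `Nc1ccccc1NC(=O)c1ccc(CSc2ccc(Br)cc2)cc1` gives 10%, and compound 2 `Nc1ccccc1NC(=O)c1ccc(CSc2ccc(Cl)cc2)cc1` gives 2.93%. Within the data shown here, the only measured step is a number 7.1 percentage points lower from compound 1 to compound 2 (within the scatter), for chloro in place of bromo on an aromatic carbon, so compound 2 stands level with compound 1 and the two cannot be told apart.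

Compound 3 `Cc1cc(C)cc(SCc2ccc(C(=O)Nc3ccccc3N)cc2)c1` differs from compound 2 by 3,5-dimethylphenyl in place of 4-chlorophenyl on a sulfur. Among the measured compounds shown here, the measured step changed only one halogen on that ring. For the measured compounds named here, no measurement yet shows what exchanging the whole ring does, so the evidence is thin and gives no firm direction.

No shift beyond the scatter is expected, and the estimated step is a number 3.1 percentage points higher from compound 2 to compound 3 (within the scatter). For compound 3 the estimated value is 6%, with an expected range from 0% to 20%.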

Compound 3, percent growth inhibition at one concentration: 29.1%
For compound 3 the middle estimate is 23.1 percentage points below the measured one; the whole stated range lies below it.
By their numbers in this assay, from the lowest: compounds 2 and 1 (each within the scatter of the next); then compound 3.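

Exchanging the whole ring on the sulfur moves the result in this assay in a way the halogen swap did not: the change to 3,5-dimethylphenyl gives a number 26.2 percentage points higher from compound 2 to compound 3 (beyond the scatter) and, starting from the bromo compound, a number 19.1 percentage points higher from compound 1 to compound 3 (beyond the scatter) in the same direction. This position therefore responds to the ring it carries, even though exchanging chloro and bromo on that ring left compound 1 and compound 2 level. No supporting measurement is available to explain why this ring gives the higher number.

The exchange removes the halogen and adds two methyl groups in one move, so the compounds shown cannot say which part matters. From the compounds shown here alone, what a ring carrying a single methyl group, an amine or a carboxylic acid would give also remains open.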